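The compounds below may be only part of what the source reports. "The series", "measured", "known", "first", "only" and "open" are said of these compounds alone.

In an ADME assay on HEp-2 cells (Homo sapiens) for cytotoxicity, with a stated time of 4 days (on this read-out higher numbers stand for lower toxicity in this test and lower numbers for higher toxicity in this test), compound 1 `CS(=O)(=O)CCn1c(Cn2cc(S(C)(=O)=O)c3ccccc32)nc2cc(Cl)ccc21` reaches only the limit of the test, > 100000 nM. Compound 2 `CS(=O)(=O)c1nn(Cc2nc3cc(Cl)ccc3n2CCCO)c2cnccc12` likewise gives only a limit in this assay, > 100000 nM. Both values shown sit at the limit of > 100000 nM in this assay, at which 2 of the 2 values shown sit, so compound 2 stands at the top of what the test can report, with no number below it to order it against. Compound 3 `CS(=O)(=O)c1nn(Cc2nc3cc(Cl)ccc3n2CC2COC2)c2cnccc12` differs from compound 2 by oxetan-3-yl in place of 2-hydroxyethyl on a saturated chain carbon bound to an aromatic nitrogen. Among the measured compounds shown here, no measured pair shows this change. The step from compound 2 to compound 3 in this assay is expected to be a number no higher from compound 2 to compound 3 (the limit leaves the size open), none beyond the scatter. Compound 3 is therefore estimated at 100000 nM, within 30000 nM to 300000 nM, most likely again only a limit.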

Compound 3, half-maximal cytotoxic concentration in the HEp-2 assay: > 100000 nM
Compound 3 was reported as a limit (the forecaster's own chance of this, stated with the estimate: 80%); the middle value lies on the limit itself.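

In the HEp-2 assay, compound 2 gives only a limit, > 100000 nM. In the HEp-2 assay, compound 3 also gives only a limit, > 100000 nM. No step can be read between them. The compounds shown leave open how compounds 1, 2 and 3 actually compare in cytotoxicity: the limit of > 100000 nM in the HEp-2 assay, at which 3 of the 3 values shown sit. In a physicochemical assay for solubility, read by spectrophotometry, in phosphate buffer, at pH 6.5 (a higher number here means a more soluble compound, a lower number a less soluble compound), compound 2 gives 40 ug/mL and compound 3 gives 4 ug/mL.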